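The source may hold more compounds than are shown below. What is called first, only, known or untested is meant among the compounds shown, and "the series" means these compounds.

Compound 1 `CCc1cc2ccccc2nc1-c1cc(-c2ccc(C)cc2)no1`: > 100000 nM
Compound 2 `CCCc1cc2ccccc2nc1-c1cc(-c2ccc(C)cc2)no1`: > 100000 nM
Compound 3 `CCCc1cc2ccccc2nc1-c1cc(-c2ccc(C(F)(F)F)cc2)no1`: 33800 nM

In a functional assay on PC-3 cells (Homo sapiens) for inhibition, read by MTT assay, with a stated time of 24 h (a lower number here means a stronger inhibitor, a higher number a weaker inhibitor), compound 1 reaches only a limit of the assay, > 100000 nM. Compound 2 likewise gives only a limit, > 100000 nM. Compound 2 differs from compound 1 by methyl in place of hydrogen on a saturated chain carbon, two bonds along the chain from an aromatic carbon, and the step that the two limits leave unreadable from compound 1 to compound 2 cannot be sized because of the limit of > 100000 nM in this assay, at which 2 of the 3 values shown sit. Within the data shown here, compound 3 is the one compound with a real number: in this assay compound 3 gives 33800 nM, a step of an at least 2.9-fold lower number from compound 2 to compound 3 (0.47 log units; beyond the scatter). How the core of compound 1 differs from the core of compound 3 is not broken down here.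

Compound 4 `CCCCc1cc2ccccc2nc1-c1cc(-c2ccc(C(F)(F)F)cc2)no1` is not yet measured. It differs from compound 3 by methyl in place of hydrogen on a saturated chain carbon, three bonds along the chain from an aromatic carbon, the same kind of change as between compound 1 and compound 2, though there the place was two bonds along the chain from an aromatic carbon and here it is three. That earlier step has no readable size, so the expectation rests on compound 3 and its value 33800 nM. The step from compound 3 to compound 4 is expected to be small, a 1.1-fold lower number from compound 3 to compound 4 (0.05 log units; within the scatter). Compound 4 is therefore estimated at 30000 nM, likely between 10000 nM and 100000 nM.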

Compound 4, half-maximal inhibitory concentration: 10800 nM
Estimate against measurement, compound 4: 2.8-fold (0.44 log units) above; the measured number falls inside the stated range.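

In this assay, the change from propyl to butyl gives a 3.1-fold lower number from compound 3 to compound 4 (0.50 log units; beyond the scatter), so on the core of compound 3 this one added methyl has a readable effect. The same kind of change on the core of compound 1, ethyl to propyl, cannot be read because both compounds stop at a limit: the limit of > 100000 nM in this assay, at which 2 of the 4 values shown sit. The data therefore show neither that the effect carries from one core to the other nor that it fails to, and the two changes also sit at different places on the chain.

Going by these compounds, whether a longer chain, such as pentyl, would lower the number further remains open. So does the effect of an amine or a carboxylic acid in place of the butyl chain.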